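This account rests on a few compounds, and the source may have more. Where it says the series, first, only, none or still open, it means among the compounds named here.

Of the compounds shown here, two sharing one core have been tested in a functional assay on THP-1 cells (Homo sapiens) for inhibition, read by ELISA, with stated times of 2 h and 48 h; a higher number here means a weaker inhibitor, a lower number a stronger inhibitor. Compound 1 `CCOC1=C(/C(C)=N/OCC(=O)Nc2ccccc2)N(C)S(=O)(=O)c2ccccc21` carries a plain phenyl on the amide-type nitrogen. In this assay compound 1 reaches only a limit of the assay, > 20000 nM, so no number is known for it. Compound 2 `CCOC1=C(/C(C)=N/OCC(=O)Nc2ccc(C(F)(F)F)cc2)N(C)S(=O)(=O)c2ccccc21` carries a trifluoromethyl on that ring, and in this assay compound 2 gives 16700 nM. Within the data shown here, the single step that can be read, an at least 1.1-fold lower number from compound 1 to compound 2 (0.07 log units; that floor lies within the scatter), is only a floor, since one of the two values sits at the limit of > 20000 nM in this assay, at which 1 of the 2 values shown sits. Among the measured compounds shown here, compound 2 therefore stands as the only compound with an actual number, and that number marks a weak inhibitor. Compound 3 `CCOC1=C(/C(C)=N/OCC(=O)Nc2ccc(F)c(Cl)c2)N(C)S(=O)(=O)c2ccccc21` differs from compound 2 by 3-chloro-4-fluorophenyl in place of 4-(trifluoromethyl)phenyl on an amide-type nitrogen. For the measured compounds named here, no measured step covers this exchange; the one step known, from hydrogen to trifluoromethyl on an aromatic carbon, is small and within the scatter. Nothing in the data points to a large shift in either direction, so the step of a 1.1-fold lower number from compound 2 to compound 3 (0.05 log units; within the scatter) is expected to stay within the scatter. My estimate for compound 3 in this assay is 15000 nM, with a range from 5000 nM to 60000 nM.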

Compound 3, half-maximal inhibitory concentration: > 20000 nM
Compound 3 ended at the assay's limit; the forecaster's own chance of this, stated with the estimate: 40%; at least 1.3-fold (0.12 log units) between middle value and limit.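

In this assay, replacing 4-(trifluoromethyl)phenyl with 3-chloro-4-fluorophenyl on the amide-type nitrogen gives an at least 1.1-fold higher number from compound 2 to compound 3 (0.07 log units; that floor lies within the scatter), so this exchange shows no change that can be told apart from repeat-to-repeat variation, although the true size of the step could be larger. Among these compounds, compound 3 stops at a limit of the assay, > 20000 nM, which is not a number, so a ring carrying chlorine and fluorine gives no measurable inhibition here, and compound 2 remains the only compound with an actual value. The steps from compound 1 to compound 3 cannot be read, and the series now rests mostly on limits rather than numbers: the limit of > 20000 nM in this assay, at which 2 of the 3 values shown sit.

The compounds shown leave open whether any group on this ring can bring the number clearly down, since all the substituents so far are halogens or trifluoromethyl, and a carboxylic acid, an amine or a nitrile would test quite different atoms at this place. They also leave open whether a saturated cyclohexyl ring in place of the aromatic ring on this nitrogen would give a readable value at all.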